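The source may hold more compounds than are shown below. What is called first, only, known or untested is meant among the compounds shown, and "the series" means these compounds.

Of the compounds shown here, two on the shared core have numbers so far in a functional assay on Bel-7402 cells (Homo sapiens) for inhibition, read by MTT assay, with a stated time of 24 h, tested at 0.1 ug/mL; a higher number here means more inhibition of growth at the concentration tested, a lower number less inhibition of growth. Compound 1 (`O=C(CCCCC1CCSS1)NO`) gives 10.4%, and compound 2 (`O=C(CCCCC1CCSS1)Nc1ccccn1`) gives 0.89%. These two values lie within the scatter of each other, so compound 2 is not separated from compound 1. Next is compound 3 (`O=C(CCCCC1CCSS1)Nc1ccc(Cl)cn1`), which differs from compound 2 as follows: chloro in place of hydrogen on an aromatic carbon. The chloro sits two atoms from the ring nitrogen, para to a large group. Among the compounds with values here, only one measured step is available, a number 9.5 percentage points lower from compound 1 to compound 2 (within the scatter), and it concerns the amide-type nitrogen, not the aromatic carbon. It gives no measured size for a chloro in place of hydrogen, so no step beyond the scatter is expected in this assay. The expected step is a number 3.1 percentage points higher from compound 2 to compound 3 (within the scatter). The estimate for compound 3 is 4%, with an expected range from 0% to 14%.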

Compound 3, percent growth inhibition at one concentration: "not active" (no number reported)
No number was reported for compound 3; there is nothing to compare the estimate with.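

Within the data shown here, compound 3 is reported as "not active" without a number in this assay, so no step from compound 2 to compound 3 can be read. No measurement on hand bears on this result. The compounds shown leave open what size of step a chloro in place of hydrogen on the aromatic carbon gives.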